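The compounds below may be only part of what the source reports. "The series", "measured", "known", "first", "only" and "open" are said of these compounds alone.

Measured compounds:
Compound 1 `C[C@H](NC1CCOc2cc(OCc3ccccc3F)ccc21)C(N)=O` gives > 79400 nM in an assay on HEK293 cells for inhibition of sodium channel protein type 3 subunit alpha (Homo sapiens), read by electrophysiology, with a stated time of 3.5 min (on this read-out higher numbers stand for weaker inhibition and lower numbers for stronger inhibition), which is a limit of the assay and not a number.
Compound 2 `NC(=O)[C@@H]1CC[C@H](c2ccc(Oc3ccc(F)cc3)cc2)N1` gives > 100000 nM in this assay, likewise a limit of the assay.
Compound 3 `NC(=O)[C@@H]1CCCN1Cc1ccc(OCc2ccccc2F)cc1` gives 79400 nM in this assay.

Compound 2 therefore stands at a limit rather than at a number: it sits at the limit of > 100000 nM in this assay, at which 1 of the 3 values shown sits. One further value shown is also a limit, at the limit of > 79400 nM in this assay, at which 1 of the 3 values shown sits, and only compound 3 gives a number at all, so none of the three is set apart from the others as stronger or weaker.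

Compound 4 `NC(=O)[C@@H]1CC[C@H](c2ccc(Oc3cccc(F)c3)cc2)N1` differs from compound 2 by 3-fluorophenyl in place of 4-fluorophenyl on an oxygen on an aromatic ring. For the measured compounds named here, no step between two measured compounds is known here, so nothing shows how this change acts in this assay. Compound 2 stands at a limit, and the step from compound 2 to compound 4 is expected to be a number no higher from compound 2 to compound 4 (the limit leaves the size open), none beyond the scatter. Compound 4 is expected to give 100000 nM in this assay, between 40000 nM and 250000 nM, most probably again as a limit rather than a number.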

Compound 4, half-maximal inhibitory concentration: 100000 nM
Estimate against measurement, compound 4: no gap at the digits printed, within the range that was stated.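

Compound 4, with 3-fluorophenyl in place of 4-fluorophenyl on an oxygen on an aromatic ring, gives a number in this assay, 100000 nM, and so sets a first measured point for this place. Compound 2 stands at a limit of the assay and not a number: the limit of > 100000 nM in this assay, at which 1 of the 4 values shown sits. The step is a number no higher from compound 2 to compound 4 (the limit leaves the size open), and its size cannot be read, so the change shows no measurable gain in inhibition, and it tells nothing about whether moving the fluorine matters at all.

The compounds shown leave open whether any other group on this oxygen, such as a 4-methoxyphenyl or a pyridine ring, would give a clearly lower value. They also leave open what a carboxylic acid would do in place of the amide on the shared core.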